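Chlorophenyl swap from compound 2 to compound 3

The source may hold more compounds than are shown below. What is called first, only, known or untested is meant among the compounds shown, and "the series" means these compounds.

compound 1 `C#CCSc1nc(NCCC(C)C)c2ccncc2n1`: > 80000 nM (a limit)
compound 2 `C#CCSc1nc(Nc2ccccc2Cl)c2ccncc2n1`: 27600 nM

Both compounds were read in a functional assay on MGC-803 cells (Homo sapiens) for inhibition, read by MTT assay, with a stated time of 72 h; on this read-out lower numbers stand for stronger inhibition and higher numbers for weaker inhibition. Compound 1 gives > 80000 nM, which is a limit of the assay and not a number. For the measured compounds named here, compound 2 gives 27600 nM, the only true number so far, and so the only firm reference point.

Compound 3 `C#CCSc1nc(Nc2cccc(Cl)c2)c2ccncc2n1` has the same atoms as compound 2, joined differently: 3-chlorophenyl in place of 2-chlorophenyl on a nitrogen on an aromatic ring. The change is 3-chlorophenyl in place of 2-chlorophenyl on a nitrogen on an aromatic ring.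

Going by the values given here, one measured step bears on this, and only indirectly: an at least 2.8-fold lower number from compound 1 to compound 2 (0.46 log units; beyond the scatter). That step replaces isopentyl with 2-chlorophenyl, so it shows that the group on this nitrogen matters in this assay. Among the compounds with values here, it does not compare two chlorophenyl groups, and no measured pair does. Within the data shown here, with only that step to go on, no change beyond the scatter is expected in this assay, in either direction.

For compound 3 the expected value is 25000 nM, with an estimated range of 8000 nM to 70000 nM. This estimate means an expected 1.1-fold lower number from compound 2 to compound 3 (0.04 log units; within the scatter).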

Compound 3, half-maximal inhibitory concentration: 2190 nM
For compound 3 the middle estimate is 11-fold (1.06 log units) above the measured one; the measured number lies below the stated range.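

In this assay, 3-chlorophenyl in place of 2-chlorophenyl on the nitrogen gives a 13-fold lower number from compound 2 to compound 3 (1.10 log units; beyond the scatter) and so a change well beyond the scatter. For the compounds shown here, the earlier compounds showed only that exchanging an alkyl group for an aryl group on this nitrogen can shift the number, whereas this pair shows that the placement of the chlorine on the phenyl ring matters on its own, with the heavy atoms of the group unchanged in kind and count. Replacing isopentyl with 3-chlorophenyl gives an at least 36-fold lower number from compound 1 to compound 3 (1.56 log units; beyond the scatter) and is larger than the step to the 2-chlorophenyl compound, but its size is only a bound, set by the limit for compound 1: the limit of > 80000 nM in this assay, at which 1 of the 3 values shown sits.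

From the compounds shown here alone, whether fluorine, a methoxy group or a nitrile in place of the chlorine of 3-chlorophenyl would hold the same gain remains open, as does the standing of an unsubstituted phenyl group on this nitrogen. The numbers also do not say why the two chlorophenyl groups differ, or whether the gain would carry over to other cell lines or to changes elsewhere on the shared core.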